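A few compounds are considered here, and "the series" means these few. Any claim that something is new, unique, unknown or untested is made for them only; others in the source may bear on it.

Compound 1 `N#Cc1c(-c2ccccc2)cn(-c2ccc(S(=O)(=O)Nc3nccs3)cc2)c1NC(N)=O` carries a urea-type group on the core, and in a functional assay on HepG2 cells (Homo sapiens) for inhibition, read by sulforhodamine B assay, with a stated time of 24 h (on this read-out lower numbers stand for stronger inhibition and higher numbers for weaker inhibition), compound 1 gives 4020 nM. Compound 2 `N#Cc1c(-c2ccccc2)cn(-c2ccc(S(=O)(=O)Nc3nccs3)cc2)c1NC(=O)CCC(=O)O` carries instead a chain ending in a carboxylic acid on the same carbonyl, and in this assay compound 2 gives 3750 nM. The step of a 1.1-fold lower number from compound 1 to compound 2 (0.03 log units; within the scatter) shows that exchanging the amino group for the 2-carboxyethyl chain made no difference that the assay can resolve, so compound 2 sits alongside compound 1 rather than apart from it.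

Compound 3 `N#Cc1c(-c2ccccc2)cn(-c2ccc(S(=O)(=O)Nc3nccs3)cc2)c1N1C(=O)CCC1=O` closes that chain onto the nitrogen, so that (2,5-dioxopyrrolidin-1-yl in place of ((2-carboxyethyl)carbonyl)amino on an aromatic carbon). Going by the values given here, the only measured step, from compound 1 to compound 2, touched the same side chain, and it stayed within the scatter. Nothing measured here speaks to the loss of both hydrogen-bond donors or to ring closure, so the expectation rests on the flat step seen so far. Compound 3 is therefore expected to give about 4000 nM, with a range from 1500 nM to 11000 nM. That estimate means a step of a 1.1-fold higher number from compound 2 to compound 3 (0.03 log units; within the scatter), which is expected to remain within the scatter.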

Compound 3, half-maximal inhibitory concentration: 4560 nM
For compound 3 the middle estimate is 1.1-fold (0.06 log units) below the measured one, and the stated range covers the measured number.
By their numbers in this assay, from the lowest: compounds 2, 1 and 3 (each within the scatter of the next).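

Closing the open chain into a ring at this aromatic carbon of the shared core leaves the numbers in this assay within the scatter of one another (a 1.2-fold higher number from compound 2 to compound 3 (0.08 log units; within the scatter)), and the same holds when the ring is set against the ureido group (a 1.1-fold higher number from compound 1 to compound 3 (0.05 log units; within the scatter)). The earlier step compared only open groups, whereas this one shows that a five-membered non-aromatic ring with 0 hydrogen-bond donors cannot be told apart in this assay from open groups that have hydrogen-bond donors. For these three compounds, then, neither the ring nor the loss of the donors produces a difference that the assay can resolve, and no independent information is available to explain this flat result.

Going by these compounds, the three groups are all fairly large and all contain carbonyl groups, so it remains open whether a plain amine, a small acetyl amide or a much longer chain at this carbon would also leave the number in the same range. On these data alone, it is also open whether this position would respond differently if the phenyl or cyano group on the core were replaced.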